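A few compounds are considered here, and "the series" means these few. Any claim that something is new, unique, unknown or untested is made for them only; others in the source may bear on it.

In an ADME assay on L02 cells (Homo sapiens) for cytotoxicity, read by MTT assay, with a stated time of 24 h (a higher number here means a weaker inhibitor, a lower number a stronger inhibitor), compound 1 `O=C1/C(=C/c2cccnc2)CN(S(=O)(=O)c2ccccc2)C/C1=C\c1ccccc1F` gives 15300 nM. Compound 2 `N#Cc1ccc(S(=O)(=O)N2C/C(=C\c3cccnc3)C(=O)/C(=C/c3ccccc3F)C2)cc1` stands at a limit of the assay, > 20000 nM, and not at a number. Compound 3 `CC(=O)Nc1ccc(S(=O)(=O)N2C/C(=C\c3cccnc3)C(=O)/C(=C/c3ccccc3F)C2)cc1` carries acetamido in place of cyano on an aromatic carbon, para to a large group: acetamido in place of cyano on an aromatic carbon. Among the measured compounds shown here, the only measured step bearing on this, an at least 1.3-fold higher number from compound 1 to compound 2 (0.11 log units; that floor lies within the scatter), puts cyano in place of hydrogen and gives only a floor, so no step beyond the scatter is expected in this assay, in either direction. The expected step is an at least 1.1-fold lower number from compound 2 to compound 3 (0.07 log units; that floor lies within the scatter). For compound 3 the estimated value is 17000 nM, with an expected range of 8000 nM to 30000 nM.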

Compound 3, half-maximal inhibitory concentration: 15600 nM
Beside the measured number, compound 3's estimate is 1.1-fold (0.04 log units) above it; the measured number falls inside the stated range.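

In this assay, acetamido on the aromatic carbon para to a large group gives a measured number where cyano gave none, and the comparison with hydrogen on that carbon stays within the scatter (a 1.0-fold higher number from compound 1 to compound 3 (0.01 log units; within the scatter)). Compound 2 stands at a limit of the assay and not at a number (> 20000 nM). The step away from it is a floor only (an at least 1.2-fold lower number from compound 2 to compound 3 (0.10 log units; that floor lies within the scatter)), and it does not rank cyano against acetamido.

From the compounds shown here alone, whether an amine or a carboxylic acid on this carbon would move the number beyond the scatter stays open. Also open, going by these compounds, is whether a longer chain in place of the acetyl part of acetamido would do so.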